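Methoxycarbonyl added to the aromatic amine of compound 3

This account rests on a few compounds, and the source may have more. Where it says the series, first, only, none or still open, it means among the compounds named here.

In an assay on COS-7 cells for inhibition of patatin-like phospholipase domain-containing protein 2 (Mus musculus) (on this read-out lower numbers stand for stronger inhibition and higher numbers for weaker inhibition), compound 1 `CCOC(=O)c1cccc(-c2ccc(N(C)C)cc2)c1` gives 40000 nM. Compound 2 `CN(C)c1ccc(-c2cccc([N+](=O)[O-])c2)cc1` reaches only a limit of this assay, > 200000 nM (the limit of > 200000 nM in this assay, at which 1 of the 3 values shown sits). Compound 3 `CN(C)c1ccc(-c2cccc(N)c2)cc1` gives 100000 nM, the highest of the two numbers shown, with compound 1 as its nearest neighbour: a 2.5-fold higher number from compound 1 to compound 3 (0.40 log units; beyond the scatter). Compound 4 `COC(=O)Nc1cccc(-c2ccc(N(C)C)cc2)c1` differs from compound 3 by methoxycarbonyl in place of hydrogen on a nitrogen on an aromatic ring. Within the data shown here, of the measured steps, only the one from compound 1 to compound 3, and the step from compound 2 to compound 3 an at least 2.0-fold lower number from compound 2 to compound 3 (0.30 log units; that floor lies within the scatter), touch the same position. Since compound 1 carries a carbonyl-bearing group there and gives 40000 nM, a modest lowering is expected in this assay, estimated as a 3.3-fold lower number from compound 3 to compound 4 (0.52 log units; beyond the scatter). Compound 4 is therefore estimated at 30000 nM, within 8000 nM to 120000 nM.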

Compound 4, half-maximal inhibitory concentration: 5000 nM
Compound 4: middle estimate off by 6.0-fold (0.78 log units), on the high side, and the stated range ends above it.
By their numbers in this assay, from the lowest: compound 4; then compound 1; then compound 3. At a limit, above all of these: compound 2.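

In this assay, among these compounds, putting methoxycarbonyl on the aromatic amine gives a 20-fold lower number from compound 3 to compound 4 (1.30 log units; beyond the scatter), the first large step at this position, so the nitrogen tolerates substitution and the capped amine outperforms the free one. The (methoxycarbonyl)amino group also improves on the ester attached directly to the ring, with an 8.0-fold lower number from compound 1 to compound 4 (0.90 log units; beyond the scatter). The step of an at least 40-fold lower number from compound 2 to compound 4 (1.60 log units; beyond the scatter) is only a floor, as compound 2 stands at a limit: the limit of > 200000 nM in this assay, at which 1 of the 4 values shown sits.

On these data alone, what remains open is how much of this depends on the methoxy end of the group. An acetyl group, a urea or a longer carbamate chain on the same nitrogen would separate these possibilities.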